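Tertiary amide replaces difluorobenzylamide on the shared core

The source may hold more compounds than are shown below. What is called first, only, known or untested is meant among the compounds shown, and "the series" means these compounds.

Measured so far:
Compound 1, `CCN(Cc1ccccc1)C(=O)c1nn(-c2ccc(F)cc2)c(OC[C@@H](O)C[C@@H](O)CC(=O)O)c1C(C)C`: 14 nM
Compound 2, `CC(C)c1c(C(=O)NCc2cccc(F)c2F)nn(-c2ccc(F)cc2)c1OC[C@@H](O)C[C@@H](O)CC(=O)O`: 2 nM

In an assay on microsomes from liver for inhibition of 3-hydroxy-3-methylglutaryl-coenzyme A reductase (Rattus norvegicus) (on this read-out lower numbers stand for stronger inhibition and higher numbers for weaker inhibition), compound 2 gives the lower of the two numbers, and its nearest neighbour is compound 1. Among the measured compounds shown here, the one step seen, a 7.0-fold lower number from compound 1 to compound 2 (0.85 log units; beyond the scatter), turned a benzyl(ethyl)amino group into a (2,3-difluorobenzyl)amino group on the carbonyl carbon. Compound 3, `Cc1ccc(CN(C)C(=O)c2nn(-c3ccc(F)cc3)c(OC[C@@H](O)C[C@@H](O)CC(=O)O)c2C(C)C)cc1`, is not yet measured. It differs from compound 2 by methyl(4-methylbenzyl)amino in place of (2,3-difluorobenzyl)amino on a carbonyl carbon. This change again removes the hydrogen-bond donor and returns to a tertiary amide of the kind seen in compound 1, so the step from compound 1 to compound 2 bears on it, in the reverse direction. Compound 3 is therefore expected to lose part of the gain, and the estimated step is a 6.0-fold higher number from compound 2 to compound 3 (0.78 log units; beyond the scatter). For compound 3 an estimate of 12 nM in this assay is expected, with a range from 4 nM to 40 nM.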

Compound 3, half-maximal inhibitory concentration: 37 nM
Compound 3: the middle estimate sits 3.1-fold (0.49 log units) below what was measured; the measured number falls inside the stated range.
By their numbers in this assay, from the lowest: compound 2; then compound 1; then compound 3.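

In this assay, the step of a 19-fold higher number from compound 2 to compound 3 (1.27 log units; beyond the scatter) places a second tertiary amide on the weaker side of compound 2, so among these three compounds the only one with the amide hydrogen gives the lowest number, and none goes against this. The two tertiary amides are also not interchangeable: the step of a 2.6-fold higher number from compound 1 to compound 3 (0.42 log units; beyond the scatter) shows that the groups on the amide nitrogen still matter once the amide hydrogen is gone. Nothing at hand explains why the numbers move in this way.

Going by these compounds, compound 3 differs from compound 2 in the amide hydrogen, the added methyl groups and the lost fluorines all at once, so the share of each remains open. A methyl(2,3-difluorobenzyl)amino group or a (4-methylbenzyl)amino group on the same carbonyl carbon would separate these changes.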